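The compounds below may be only part of what the source reports. "The series", "measured", "known", "first", "only" and "open" are said of these compounds alone.

Measured compounds: compound 1 `O=C1OC(Cc2nc(Cc3ccccc3)no2)c2ccccc21`; compound 2 `COCCCCOc1ccc(C(O)C2OC(=O)c3c(OC)cc(OC)cc32)cc1`.

In an ADME assay on RAW264.7 cells (Mus musculus) for cytotoxicity, read by MTT assay, with a stated time of 24 h, in the presence of a further agent that is not named here (a lower number here means a stronger inhibitor, a higher number a weaker inhibitor), compound 1 gives > 40000 nM, a limit of the assay rather than a number. In this assay compound 2 gives > 40000 nM, again a limit of the assay. Compound 2 therefore stands at the limit of > 40000 nM in this assay, at which 2 of the 2 values shown sit, with nothing placing it apart from compound 1. Compound 3 `COc1cc(OC)c2c(c1)C(C(O)c1ccc(OCc3ccc(OC(F)F)cc3)cc1)OC2=O` differs from compound 2 by 4-(difluoromethoxy)phenyl in place of 3-methoxypropyl on a saturated chain carbon bound to an oxygen on an aromatic ring. Within the data shown here, no measured step between two compounds is available, so for this change no step beyond the usual scatter in this assay is expected, in either direction. Compound 3 is accordingly expected to give 60000 nM, with a range from 20000 nM to 200000 nM. The expected step is a step that the limit leaves unreadable from compound 2 to compound 3.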

Compound 3, half-maximal inhibitory concentration: > 40000 nM
Compound 3 was reported as a limit (the forecaster's own chance of this, stated with the estimate: 80%); the middle value is on the limit's open side.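

Compound 2 and compound 3 both sit at a limit of the assay rather than at a number, so no step can be read between them: the limit of > 40000 nM in this assay, at which 3 of the 3 values shown sit. What concentration, if any, would give a measurable effect in this assay remains open for all the compounds shown.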